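Replacing the two-ring group of compound 2 with pyridin-3-yl

A few compounds are considered here, and "the series" means these few. Any claim that something is new, unique, unknown or untested is made for them only; others in the source may bear on it.

In a functional assay for inhibition, with Homo sapiens as the target (on this read-out lower numbers stand for stronger inhibition and higher numbers for weaker inhibition), compound 1 (`CC(C)(C)Sc1c(CC(C)(C)C(=O)O)n(Cc2ccc(Cl)cc2)c2ccc(CCc3ccc4ccccc4n3)cc12`) gives 4 nM and compound 3 (`COc1ccc2nc(COc3ccc4c(c3)c(SC(C)(C)C)c(CC(C)(C)C(=O)O)n4Cc3ccc(Cl)cc3)sc2c1`) gives 8 nM while compound 2 (`CC(C)(C)Sc1c(CC(C)(C)C(=O)O)n(Cc2ccc(Cl)cc2)c2ccc(OCc3ccc4cc(F)c(F)cc4n3)cc12`) gives 7 nM and so stands within the scatter of both. Compound 4 (`CC(C)(C)Sc1c(CC(C)(C)C(=O)O)n(Cc2ccc(Cl)cc2)c2ccc(OCc3cccnc3)cc12`) is still unmeasured. The change is a group of 6 heavy atoms (5 carbon, 1 nitrogen; one six-membered aromatic ring with 1 hetero atom) in place of a group of 12 heavy atoms (9 carbon, 1 nitrogen, 2 fluorine; one six-membered aromatic ring of carbon only, one six-membered aromatic ring with 1 hetero atom), on a saturated chain carbon bound to an oxygen on an aromatic ring and the entering group is pyridin-3-yl. Going by the values given here, the one measured step at this place (a 1.1-fold higher number from compound 2 to compound 3 (0.06 log units; within the scatter)) lies within the scatter, but it exchanges one two-ring group for another. Among the compounds with values here, no measured compound carries a single ring here, so the data give only a weak guide. A step towards weaker inhibition in this assay is expected (a 7.1-fold higher number from compound 2 to compound 4 (0.85 log units; beyond the scatter)). Compound 4 is estimated at 50 nM (range 12 nM to 250 nM).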

Compound 4, half-maximal inhibitory concentration: 8 nM
The estimate for compound 4 lay 6.3-fold (0.80 log units) above the measured number; the measured number lies below the stated range.
By their numbers in this assay, from the lowest: compounds 1, 2, 3 and 4 (each within the scatter of the next).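

In this assay, a single ring at the saturated chain carbon bound to an oxygen on an aromatic ring reads level with the two-ring groups: pyridin-3-yl stays within the scatter of both the larger group of compound 2 (a 1.1-fold higher number from compound 2 to compound 4 (0.06 log units; within the scatter)) and 6-methoxy-1,3-benzothiazol-2-yl (no change at the digits printed from compound 3 to compound 4 (within the scatter)). The second ring therefore adds nothing measurable among these compounds, and (pyridin-3-yl)methoxy in place of 2-(quinolin-2-yl)ethyl on an aromatic carbon also stays within the scatter (a 2.0-fold higher number from compound 1 to compound 4 (0.30 log units; within the scatter)). Nothing available accounts for this flat read-out.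

Open: whether phenyl, without the ring nitrogen, reads the same, and whether piperidin-4-yl or a carboxylic acid at this place does.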